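Series notes: aryl substitution on the shared core, compound 4

The compounds below may be only part of what the source reports. "The series", "measured", "known", "first", "only" and "open" are said of these compounds alone.

Of the compounds shown here, three have numbers so far. Compound 1 `Nc1nc(NCc2ccccc2)nc(-c2ccccc2CO)n1` gives 4.35 in a functional assay on cells for positive allosteric modulation of G-protein coupled receptor 68 (Homo sapiens), read by a luciferase reporter and cAMP accumulation, with a stated time of 30 min, at pH 6.8 and pH 8.3, in the presence of a further agent that is not named here; on this read-out higher numbers stand for higher potency (the scale is a negative logarithm) and lower numbers for lower potency. Compound 2 `NCc1ccccc1-c1nc(N)nc(NCc2ccccc2)n1` gives 3.86. Compound 3 `Nc1nc(NCc2ccccc2)nc(-c2ccc(Cl)cc2CO)n1` gives 4.76, the highest of the three, with compound 1 the nearest and compound 2 the furthest from it. The step of a number 0.49 log units lower from compound 1 to compound 2 (beyond the scatter) concerns a different place and does not bear on the present change. Within the data shown here, the step of a number 0.41 log units higher from compound 1 to compound 3 (beyond the scatter) does bear on it, since it sits at the same aromatic carbon; it is the only measured step at that carbon.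

Compound 4 `CCOc1ccc(-c2nc(N)nc(NCc3ccccc3)n2)c(CO)c1` differs from compound 3 by ethoxy in place of chloro on an aromatic carbon. Among the measured compounds shown here, there is no measured pair in which ethoxy stands against either chloro or hydrogen at this carbon, so the direction of the step is open. For the measured compounds named here, the one relevant step, from hydrogen to chloro, was modest, and a change from one substituent to another at the same carbon is expected to stay within a similar span, with no clear sign. Compound 4 is therefore expected to give 4.55, with a range from 3.95 to 5.15. The step of a number 0.21 log units lower from compound 3 to compound 4 (within the scatter) is expected to stay near the scatter.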

Compound 4, negative logarithm of the antagonist equilibrium constant: 4.37
Beside the measured number, compound 4's estimate is 0.18 log units above it, and the stated range covers the measured number.
By their numbers in this assay, from the lowest: compound 2; then compounds 1 and 4 (each within the scatter of the next); then compound 3.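

At the aromatic carbon para to a large group, the result in this assay shows that the substituent's identity matters and not merely that the hydrogen is replaced: exchanging chloro for ethoxy gives a number 0.39 log units lower from compound 3 to compound 4 (beyond the scatter). The comparison with hydrogen gives a number 0.02 log units higher from compound 1 to compound 4 (within the scatter), so ethoxy cannot be told apart from hydrogen here, while chloro stands clear of hydrogen with a number 0.41 log units higher from compound 1 to compound 3 (beyond the scatter); the gain at this carbon therefore belongs to chloro and does not extend to every substituent, at least not to ethoxy. No measurement at hand accounts for the difference between chloro and ethoxy at this carbon.

As far as these compounds go, with only hydrogen, chloro and ethoxy at this carbon, it remains open whether the gain is confined to chloro or would also appear with bromo, fluoro or trifluoromethyl, and whether methoxy or a longer chain such as propoxy would behave as ethoxy does. From the compounds shown here alone, it is also open whether chloro would give a similar step on the aminomethyl counterpart, compound 2, where the hydroxymethyl group is replaced.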